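The compounds below may be only part of what the source reports. "The series", "measured", "known", "first", "only" and "open" are said of these compounds alone.

Measured compounds:
compound 1, `CCCCNC(=S)N1[C@@H](CO)[C@H](O)[C@@H](O)[C@@H]1CO`: 473000 nM
compound 2, `CCCCCC/N=C1/SC[C@H]2[C@H](O)[C@@H](O)[C@H](CO)N12`: 599000 nM

Compound 1, `CCCCNC(=S)N1[C@@H](CO)[C@H](O)[C@@H](O)[C@@H]1CO`, gives 473000 nM in an assay for inhibition of beta-galactosidase (Bos taurus), read by spectrophotometry (on this read-out lower numbers stand for stronger inhibition and higher numbers for weaker inhibition), the lower of the two numbers recorded; compound 2, `CCCCCC/N=C1/SC[C@H]2[C@H](O)[C@@H](O)[C@H](CO)N12`, gives 599000 nM in this assay, and the gap between these two values lies within the scatter, so no order between compound 1 and compound 2 can be read from them. Compound 3, `CCCCCCCCCCCCNC(=S)N1[C@@H](CO)[C@H](O)[C@@H](O)[C@@H]1CO`, has not yet been measured in this assay. It differs from compound 1 in one place: octyl in place of hydrogen on a saturated chain carbon, four bonds along the chain from an amide-type nitrogen. Within the data shown here, no step between two measured compounds shows what lengthening the chain in this way does, so the expectation rests on the value of compound 1 alone and on the change itself. A moderate step toward a lower number is expected, though a step of no more than the scatter cannot be excluded. For compound 3 a value of 200000 nM is estimated, with a range from 50000 nM to 800000 nM. This estimate means an expected step of a 2.4-fold lower number from compound 1 to compound 3 (0.37 log units; beyond the scatter) in this assay.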

Compound 3, half-maximal inhibitory concentration: 30000 nM
Estimate against measurement, compound 3: 6.7-fold (0.82 log units) above, outside the stated range (below it).
By their numbers in this assay, from the lowest: compound 3; then compounds 1 and 2 (each within the scatter of the next).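

In this assay, octyl in place of hydrogen on a saturated chain carbon, four bonds along the chain from an amide-type nitrogen, gives a 16-fold lower number from compound 1 to compound 3 (1.20 log units; beyond the scatter) and so marks this place on the chain as one where a change can move the number strongly. Before this pair, no step between measured compounds spoke to this position, as compound 1 and compound 2 differ in more than one place, whereas this single change now gives the series its first direct reading of a longer chain. Nothing on hand explains the size of this step, so it stands as an observation about one change at one place and carries no cause.

Among these compounds, whether the number falls steadily as the chain grows, levels off at some length, or rises again with a longer chain cannot be told from only two chain lengths on the core of compound 1. As far as these compounds go, it also remains open whether a plain carbon chain is needed at this place, or whether a phenyl ring, an amine or a carboxylic acid carried on the chain would give a similar step in this assay.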